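Methyl to hydrogen on compound 1

The source may hold more compounds than are shown below. What is called first, only, known or untested is meant among the compounds shown, and "the series" means these compounds.

Measured in an ADME assay on Huh-7 cells (Homo sapiens) for cytotoxicity, read by MTT assay, with a stated time of 96 h; a higher number here means that more compound is tolerated, a lower number that less compound is tolerated:
- compound 1 `COc1ccc(-c2cnco2)cc1NCc1ccc(C)s1`: 52900 nM
- compound 2 `COc1cc(NCc2scnc2C)ccc1-c1cnco1`: 58500 nM

In this assay, among the compounds with values here, compound 1 at 52900 nM and compound 2 at 58500 nM lie within the scatter of each other, so neither stands apart and compound 1 sits level with the only other measured value. Both compounds are tolerated to a similar concentration.

The next compound to be read is compound 3 `COc1ccc(-c2cnco2)cc1NCc1cccs1`. It differs from compound 1 by one change: hydrogen in place of methyl on an aromatic carbon. Hydrogen takes the place of methyl on an aromatic carbon next to the ring sulfur, turning 5-methylthiophen-2-yl into thiophen-2-yl.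

Within the data shown here, no measured pair isolates a single change, so the data offer no direct guide to this step. With so small a change, no shift beyond the scatter is expected in either direction. The expected move is a 1.1-fold higher number from compound 1 to compound 3 (0.04 log units; within the scatter), an estimate that stays within the scatter. In this assay the expected value for compound 3 is 58000 nM, with an estimated range from 30000 nM to 110000 nM.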

Compound 3, half-maximal cytotoxic concentration: > 100000 nM
Compound 3 was reported as a limit (the forecaster's own chance of this, stated with the estimate: 15%); middle value at least 1.7-fold (0.23 log units) from the limit.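

In this assay compound 3 is reported only as a limit, > 100000 nM. Hydrogen in place of methyl on an aromatic carbon next to the ring sulfur gives an at least 1.8-fold higher number from compound 1 to compound 3 (0.27 log units; that floor lies within the scatter), the first step in the series that isolates a single change, and it shows that this position can go without the methyl with no fall in the tolerated concentration. The step is a floor and its true size remains unresolved, so the data cannot separate a real rise from scatter, and the reading is capped by one value: the limit of > 100000 nM in this assay, at which 1 of the 3 values shown sits.

Still open, from the compounds shown here alone, is how this position responds to anything other than methyl and hydrogen, such as a chlorine atom, a longer chain such as ethyl, or an aminomethyl group, and whether any of these would bring the tolerated concentration down from the level of compound 1 or hold it at the level of compound 3. Also open, going by these compounds, is whether the same exchange of methyl for hydrogen would read the same way on a ring other than thiophene.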